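The source may report more compounds than this note shows. Statements on the series, on what has been measured and on what is new or still open speak of the compounds shown alone.

Compound 1 `CCCC(=O)Nc1ccc(S(=O)(=O)Oc2ccccc2C(C)C)cc1`: 6600 nM
Compound 2 `CC(C)c1ccccc1OS(=O)(=O)c1ccc(NC(=O)CCl)cc1`: 2900 nM

Going by the values given here, in a functional assay on MCF7 cells (Homo sapiens) for antiproliferative activity, read by sulforhodamine B assay, with a stated time of 48 h (on this read-out lower numbers stand for stronger inhibition and higher numbers for weaker inhibition), compound 2 gives 2900 nM, the lower of the two numbers measured so far, while compound 1 gives 6600 nM. Among the compounds with values here, the only measured step so far is a 2.3-fold lower number from compound 1 to compound 2 (0.36 log units; beyond the scatter), which came from chloro in place of ethyl on a saturated chain carbon bound to a carbonyl carbon.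

Compound 3 `CC(C)c1ccccc1OS(=O)(=O)c1ccc(NC(=O)CCCl)cc1` has not yet been tested. It differs from compound 2 by chloromethyl in place of chloro on a saturated chain carbon bound to a carbonyl carbon. Within the data shown here, no measured step covers this exact change, so the step from compound 1 to compound 2 is the only guide, and it shows that altering the group on that saturated chain carbon moves the number by a modest amount. Since compound 3 keeps a chlorine but lengthens the chain that compound 1 also carries, a number pulling back toward that of compound 1 is expected, with a 1.7-fold higher number from compound 2 to compound 3 (0.24 log units; within the scatter). Compound 3 is therefore estimated at 5000 nM, within 2000 nM to 14000 nM.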

Compound 3, half-maximal inhibitory concentration: 9000 nM
Beside the measured number, compound 3's estimate is 1.8-fold (0.26 log units) below it; the range from low to high includes it.
By their numbers in this assay, from the lowest: compound 2; then compounds 1 and 3 (each within the scatter of the next).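

In this assay, going from chloromethyl to 2-chloroethyl on the carbonyl gives a 3.1-fold higher number from compound 2 to compound 3 (0.49 log units; beyond the scatter), so the lower number of compound 2 does not carry over once the chlorine-bearing chain gains a carbon. The other comparison gives a 1.4-fold higher number from compound 1 to compound 3 (0.13 log units; within the scatter), with chloro in place of methyl at the chain end, so at this chain length the chlorine leaves the number indistinguishable from that of the chlorine-free chain. No measurement shown here explains why the shorter chlorine-bearing chain stands apart.

From the compounds shown here alone, whether a bromine or an amine in place of the chlorine of compound 2 would keep its lower number remains open. So does the question of how a still longer chain ending in chlorine would behave.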